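Chloro substitution on the benzoyl of the hydroxyanilide

The compounds below may be only part of what the source reports. "The series", "measured", "known", "first", "only" and "open" are said of these compounds alone.

Two compounds of the shared core have been run in a functional assay on ACHN cells (Homo sapiens) for cytotoxicity, read by sulforhodamine B assay, with a stated time of 72 h; on this read-out higher numbers stand for weaker inhibition of growth and lower numbers for stronger inhibition of growth. Compound 1 `O=C(Nc1ccccc1C(F)(F)F)C1CCc2ccccc2N1C(=O)c1cccc(Cl)c1` gives 526 nM in this assay. Compound 2 `O=C(Nc1ccccc1O)C1CCc2ccccc2N1C(=O)c1ccccc1` gives 4260 nM in this assay, the higher of the two numbers; the gap to compound 1 lies beyond the scatter, but the two compounds differ in two places, so no single step can be read from them. Compound 3 `O=C(Nc1ccccc1O)C1CCc2ccccc2N1C(=O)c1cccc(Cl)c1` is the unmeasured member: it differs from compound 2 only by chloro in place of hydrogen on an aromatic carbon, placed meta to the large group, which gives the same benzoyl substitution pattern as compound 1 while keeping the hydroxy anilide of compound 2. Among the compounds with values here, no measured pair isolates this change. The expectation for compound 3 is a step from compound 2 of a 2.4-fold lower number from compound 2 to compound 3 (0.37 log units; beyond the scatter), toward stronger inhibition of growth but modest and of uncertain size. Compound 3 is therefore estimated at 1800 nM, within 700 nM to 5000 nM.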

Compound 3, concentration for 50% growth inhibition: 17200 nM
Compound 3: middle estimate off by 9.6-fold (0.98 log units), on the low side, outside the stated range (above it).
By their numbers in this assay, from the lowest: compound 1; then compound 2; then compound 3.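

In this assay, the change from benzoyl to (3-chlorophenyl)carbonyl on the hydroxy anilide runs toward weaker inhibition of growth, a 4.0-fold higher number from compound 2 to compound 3 (0.61 log units; beyond the scatter), so at this position chloro in place of hydrogen costs activity in this pair. With the (3-chlorophenyl)carbonyl held fixed, the anilide now gives a readable step of its own, a 33-fold higher number from compound 1 to compound 3 (1.51 log units; beyond the scatter), for hydroxy in place of trifluoromethyl on an aromatic carbon, and this large step runs toward weaker inhibition of growth for the hydroxy anilide. Nothing available on these compounds explains either step.

Whether chloro has the same effect on the trifluoromethyl anilide stays open, since the compounds shown include no benzoyl partner of compound 1. Also open, from the compounds shown here alone, is how fluoro or methyl at the chloro position, or methoxy or an amine in place of hydroxy on the anilide, would read in this assay.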